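The compounds below may be only part of what the source reports. "The series", "measured", "known", "first", "only" and "open" are said of these compounds alone.

Compound 3 `CC1=NC(C)=C([N+](=O)[O-])C(c2cccc(Cl)n2)/C1=C(/O)OCCc1ccccc1` gives 1510 nM in a functional assay (muscle tissue) with Cavia porcellus as the target (a lower number here means a stronger inhibitor, a higher number a weaker inhibitor), the lowest number of the three measured; compound 2 `CC1=NC(C)=C([N+](=O)[O-])C(c2ncccc2C)/C1=C(/O)OCCc1ccccc1` gives 5430 nM and compound 1 `CC1=NC(C)=C([N+](=O)[O-])C(c2cccc(C)n2)/C1=C(/O)OCCc1ccccc1` gives 9980 nM in this assay. Compound 4 `CC1=NC(C)=C([N+](=O)[O-])C(c2ncccc2[N+](=O)[O-])/C1=C(/O)OCCc1ccccc1` is not yet measured; its change from compound 3 is 3-nitropyridin-2-yl in place of 6-chloropyridin-2-yl on a saturated ring carbon. Bearing on it are a 1.8-fold lower number from compound 1 to compound 2 (0.26 log units; within the scatter), which exchanged 6-methylpyridin-2-yl for 3-methylpyridin-2-yl, and a 3.6-fold lower number from compound 2 to compound 3 (0.56 log units; beyond the scatter) together with a 6.6-fold lower number from compound 1 to compound 3 (0.82 log units; beyond the scatter), both toward the chloro. Going by the values given here, no measured pair covers the nitro group on the pyridin-2-yl. Compound 4 is therefore expected to come out somewhat weaker, a 2.3-fold higher number from compound 3 to compound 4 (0.37 log units; beyond the scatter). Compound 4 is estimated at 3500 nM in this assay, with a range from 900 nM to 14000 nM.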

Compound 4, half-maximal inhibitory concentration: 77700 nM
Compound 4: the middle estimate sits 22-fold (1.35 log units) below what was measured, outside the stated range (above it).
By their numbers in this assay, from the lowest: compound 3; then compounds 2 and 1 (each within the scatter of the next); then compound 4.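

Going by these compounds alone, on the saturated ring carbon, 3-nitropyridin-2-yl gives the weakest compound so far in this assay, with a 51-fold higher number from compound 3 to compound 4 (1.71 log units; beyond the scatter) and a 14-fold higher number from compound 2 to compound 4 (1.16 log units; beyond the scatter) and also a 7.8-fold higher number from compound 1 to compound 4 (0.89 log units; beyond the scatter) in the same direction. The methyl-to-nitro exchange on the aromatic carbon shows that this substituent can cost far more activity than the earlier methyl and chloro exchanges changed it. No measured evidence accounts for this loss.

The compounds shown do not separate the nitro group from its place on the pyridin-2-yl. A 6-nitropyridin-2-yl, a 3-chloropyridin-2-yl, or an amine or nitrile on the same carbon would address that.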